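The compounds below may be only part of what the source reports. "The series", "measured", "known", "first", "only" and "open" are said of these compounds alone.

Compound 2 `Fc1ccc(-c2cn3ccnc3c(-c3ccc4ncn(C5CCCCC5)c4c3)n2)cc1` gives 9.54% in a functional assay on OVCAR-8 cells (Homo sapiens) for inhibition, read by sulforhodamine B assay, with a stated time of 48 h, tested at 10 uM; a higher number here means more inhibition at the concentration tested (going by the name of the read-out), a lower number less inhibition; compound 1 `Brc1cn2ccnc2c(-c2ccc3ncn(C4CCCCC4)c3c2)n1`, which gives 4.92%, does not separate from it beyond the scatter, so compound 2 stands apart from nothing measured. Compound 3 `c1cn2cc(-c3ccsc3)nc(-c3ccc4ncn(C5CCCCC5)c4c3)c2n1` differs from compound 2 by thiophen-3-yl in place of 4-fluorophenyl on an aromatic carbon. Within the data shown here, the only step bearing on this change is the replacement at the same aromatic carbon, a number 4.6 percentage points higher from compound 1 to compound 2 (within the scatter), which stayed within the scatter and left both numbers low. The step of a number 1.5 percentage points lower from compound 2 to compound 3 (within the scatter) is therefore expected to be small, with no direction beyond the scatter. Compound 3 is estimated at 8%, within -5% to 22%.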

Compound 3, a percentage reported as inhibition, at one concentration (the size of the read-out at that concentration, not a potency): 12.1%
The estimate for compound 3 lay 4.1 percentage points below the measured number; the range from low to high includes it.
By their numbers in this assay, from the lowest: compounds 1, 2 and 3 (each within the scatter of the next).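

In this assay the change to thiophen-3-yl at this aromatic carbon gives a number 2.6 percentage points higher from compound 2 to compound 3 (within the scatter) when it replaces 4-fluorophenyl and a number 7.2 percentage points higher from compound 1 to compound 3 (within the scatter) when it replaces bromo. A five-membered aromatic ring with a hetero atom therefore does not separate from the six-membered aromatic ring of carbon only, and bromo, 4-fluorophenyl and thiophen-3-yl all remain within the scatter at this position. No evidence available here bears on this result.

Open, from the compounds shown here alone, is whether an amine or a carboxylic acid at this aromatic carbon would separate from these three groups. Also open, going by these compounds, is whether any change elsewhere on the shared core would lift the numbers.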